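Replacing the carboxy of compound 2 with a dimethylaminoethyl chain

The compounds below may be only part of what the source reports. "The series", "measured", "known", "first", "only" and "open" are said of these compounds alone.

Compound 1, `COC(=O)CN(C)Cc1c(OC)cc(OC)c(C(=O)/C=C/c2ccccc2Cl)c1O`: 13900 nM
Compound 2, `COc1cc(OC)c(C(=O)/C=C/c2ccccc2Cl)c(O)c1CN(C)CC(=O)O`: 44400 nM

In a functional assay on ECa-109 cells (Homo sapiens) for antiproliferative activity, with a stated time of 72 h (a lower number here means a stronger inhibitor, a higher number a weaker inhibitor), compound 2 stands highest of the two numbers, with compound 1 nearest at a 3.2-fold higher number from compound 1 to compound 2 (0.50 log units; beyond the scatter). Compound 3, `COc1cc(OC)c(C(=O)/C=C/c2ccccc2Cl)c(O)c1CN(C)CCCN(C)C`, differs from compound 2 by 2-(dimethylamino)ethyl in place of carboxy on a saturated chain carbon bound to an amine nitrogen. Among the measured compounds shown here, no measured step covers this exchange; the one step known concerns the ester of compound 1 against the acid of compound 2, where the acid gave the weaker result. Removing that carboxy is therefore expected to give a lower number, around the size of the known step. Compound 3 is estimated at 9000 nM (range 2500 nM to 32000 nM), which means an expected step of a 4.9-fold lower number from compound 2 to compound 3 (0.69 log units; beyond the scatter).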

Compound 3, half-maximal inhibitory concentration: 3800 nM
The estimate for compound 3 lay 2.4-fold (0.37 log units) above the measured number; the measured number falls inside the stated range.
By their numbers in this assay, from the lowest: compound 3; then compound 1; then compound 2.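

In this assay, the end of this side chain turned out to allow more than the exchange of ester for acid had shown: 2-(dimethylamino)ethyl in place of carboxy gave (a 12-fold lower number from compound 2 to compound 3 (1.07 log units; beyond the scatter)). The same group in place of methoxycarbonyl still gave (a 3.7-fold lower number from compound 1 to compound 3 (0.56 log units; beyond the scatter)), so the gain is more than the loss of the acid. No measurement on hand explains this gain.

The compounds shown leave open whether a morpholine or pyrrolidine at the chain end would serve as well. They also leave open how a shorter or longer chain carrying the dimethylamino group would compare.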